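Replacing Ethyl with Hydrogen on the Shared Core

The compounds below may be only part of what the source reports. "The series", "measured", "known", "first", "only" and "open" are said of these compounds alone.

In a functional assay on MT4 cells (Homo sapiens), read by MTT assay (on this read-out lower numbers stand for higher toxicity in this test and higher numbers for lower toxicity in this test), compound 2 (`C#C[C@]1(CO)O[C@@H](n2cc(CC)c(=O)[nH]c2=O)C[C@@H]1O`) gives > 360000 nM, which is a limit and not a number. Compound 1 (`C#C[C@]1(CO)O[C@@H](n2cc(C)c(=O)[nH]c2=O)C[C@@H]1O`) gives > 380000 nM, also a limit. Compound 3 (`C#C[C@]1(CO)O[C@@H](n2ccc(=O)[nH]c2=O)C[C@@H]1O`) carries hydrogen in place of ethyl on an aromatic carbon of compound 2: hydrogen in place of ethyl on an aromatic carbon. Among the compounds with values here, the only measured step bearing on this change is a step that the two limits leave unreadable from compound 1 to compound 2, so it offers no size to carry over. No change beyond the scatter is therefore expected in this assay, and the expected step is a step that the limit leaves unreadable from compound 2 to compound 3. For compound 3 the estimated value is 400000 nM, with an expected range of 150000 nM to 600000 nM.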

Compound 3, half-maximal cytotoxic concentration: > 100000 nM
Compound 3: only a limit was reported; the forecaster's own chance of this, stated with the estimate: 75%; the middle value does not contradict the limit.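

Within the data shown here, no step among compound 1, compound 2 and compound 3 can be read: all three values are limits, not numbers. These compounds leave open whether hydrogen, methyl and ethyl on this aromatic carbon differ at all in this assay.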